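The source may hold more compounds than are shown below. What is called first, only, known or untested is meant among the compounds shown, and "the series" means these compounds.

Measured compounds:
compound 1 `COc1cc(-c2cc(/C=C/C(=O)c3ccc(N)cc3)[nH]n2)cc(OC)c1OC`: -78%
compound 2 `COc1ccc(C(=O)/C=C/c2cc(-c3cc(OC)c(OC)c(OC)c3)n[nH]2)cc1`: -92%

In a functional assay on LOX IMVI cells (Homo sapiens) for cytotoxicity, read by sulforhodamine B assay, with a stated time of 48 h, tested at 10 uM (on this read-out higher numbers stand for a weaker effect at the one concentration tested and lower numbers for a stronger effect), compound 1 gives -78% and stands highest of the two numbers. Within the data shown here, its only neighbour is compound 2, which in this assay gives -92%; the one recorded step, a number 14 percentage points lower from compound 1 to compound 2 (beyond the scatter), is modest and beyond the scatter, and it concerns the group on the other ring of the shared core.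

Compound 3 `COc1ccc(-c2cc(/C=C/C(=O)c3ccc(N)cc3)[nH]n2)cc1OC` is not yet measured. It differs from compound 1 as follows: hydrogen in place of methoxy on an aromatic carbon. Among the measured compounds shown here, no measured step touches this kind of change: the single step in hand swaps methoxy for amino, not methoxy for hydrogen, and sits at a different place. The step from compound 1 to compound 3 therefore has no direct precedent among the numbers shown, and the expectation rests on compound 1 alone.

For compound 3 the estimate in this assay is -65%, with a range from -92% to -25%, the expected step being a number 13 percentage points higher from compound 1 to compound 3 (beyond the scatter), which is taken to lie close to the scatter rather than clearly beyond it.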

Compound 3, a percentage reported as activity, at one concentration (the size of the read-out at that concentration, not a potency): -66%
Estimate against measurement, compound 3: 1 percentage points above, and the stated range covers the measured number.
By their numbers in this assay, from the lowest: compound 2; then compound 1; then compound 3.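

In this assay, hydrogen in place of methoxy on an aromatic carbon, ortho to a methoxy group and meta to a large group, gives a number 12 percentage points higher from compound 1 to compound 3 (beyond the scatter), the first sign that this position on the six-membered aromatic ring of carbon only bears on the read-out. The change weakens the effect at the one concentration tested without abolishing it: compound 3 gives -66%, a number with the same sign as that of compound 1, so within this pair the methoxy contributes to the effect but the effect does not depend on it entirely. Nothing in hand explains the size of this step or says what the methoxy does at this position.

The compounds shown leave open whether the loss tracks the methoxy itself or merely the presence of any group there, a question that a hydroxyl, a fluorine or an ethoxy at the same carbon would address. They also leave open whether the same step appears when the amino on the other ring is replaced by methoxy, and what removing either remaining methoxy would do.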